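The source may report more compounds than this note shows. Statements on the series, on what has been measured and on what is new or still open speak of the compounds shown alone.

Three compounds that share one core and differ only in the ring on the sulfonamide nitrogen have been measured in a physicochemical assay for solubility; a higher number here means a more soluble compound, a lower number a less soluble compound. Compound 1 `Cn1nccc1-c1cc(C(F)(F)F)ccc1[C@H]1CCOc2cc(S(=O)(=O)Nc3nccs3)ccc21` gives 83000 nM, compound 2 `Cn1nccc1-c1cc(C(F)(F)F)ccc1[C@H]1CCOc2cc(S(=O)(=O)Nc3cccc(F)n3)ccc21` gives 27000 nM, and compound 3 `Cn1nccc1-c1cc(C(F)(F)F)ccc1[C@H]1CCOc2cc(S(=O)(=O)Nc3ncccn3)ccc21` gives 532000 nM, the highest of the three numbers. The lead of compound 3 is clear, with a 6.4-fold higher number from compound 1 to compound 3 (0.81 log units; beyond the scatter) and, larger still, a 20-fold higher number from compound 2 to compound 3 (1.29 log units; beyond the scatter).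

Compound 4 `Cn1nccc1-c1cc(C(F)(F)F)ccc1[C@H]1CCOc2cc(S(=O)(=O)Nc3ccc(F)cn3)ccc21` has not yet been measured. It carries 5-fluoropyridin-2-yl in place of pyrimidin-2-yl on a sulfonamide nitrogen, (5-fluoropyridin-2-yl in place of pyrimidin-2-yl on a sulfonamide nitrogen).

The closest guide is compound 2, which also has a fluorine-bearing pyridine ring on that nitrogen, though with the fluorine placed differently. Its step to the pyrimidine is the largest in the series, a 20-fold higher number from compound 2 to compound 3 (1.29 log units; beyond the scatter), and the modest 3.1-fold lower number from compound 1 to compound 2 (0.49 log units; beyond the scatter) likewise leaves that ring lowest of the three. How much the fluorine's placement matters has not been measured, so the range must stay wide. A large fall in this assay is therefore expected, with an estimated 15-fold lower number from compound 3 to compound 4 (1.18 log units; beyond the scatter). Compound 4 is expected to give about 35000 nM, within an estimated range of 10000 nM to 120000 nM.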

Compound 4, solubility: 29000 nM
Compound 4: the middle estimate sits 1.2-fold (0.08 log units) above what was measured, and the stated range covers the measured number.
By their numbers in this assay, from the lowest: compounds 2 and 4 (each within the scatter of the next); then compound 1; then compound 3.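

Exchanging 6-fluoropyridin-2-yl for 5-fluoropyridin-2-yl on a sulfonamide nitrogen makes no readable difference in this assay (a 1.1-fold higher number from compound 2 to compound 4 (0.03 log units; within the scatter)), so among these two rings the place of the fluorine does not separate the compounds. The second fluoropyridine also falls well short of pyrimidin-2-yl (an 18-fold lower number from compound 3 to compound 4 (1.26 log units; beyond the scatter)) and modestly short of 1,3-thiazol-2-yl (a 2.9-fold lower number from compound 1 to compound 4 (0.46 log units; beyond the scatter)), which means the low result of compound 2 was not a peculiarity of one fluorine placement, and compound 3 remains alone at the top of the four. Nothing available here accounts for this order of the rings.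

From the compounds shown here alone, it remains open whether the high number of compound 3, at 532000 nM, would survive a fluorine, a methoxy group or an amine added to its pyrimidin-2-yl ring. The compounds shown also leave open where the plain pyridin-2-yl ring or a pyrazin-2-yl ring would fall on this nitrogen, and so whether the fluorine or the ring itself sets the lower level of compound 2 and compound 4.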